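Replacing a Hexyl Amide with a Piperazine Amide

A few compounds are considered here, and "the series" means these few. Any claim that something is new, unique, unknown or untested is made for them only; others in the source may bear on it.

Compound 1 `CCCCCNC(=O)CC1CCc2cc(OC)c(OC)cc21` is one of two measured compounds. In a functional assay on the whole organism (strain Wistar) for inhibition, with Rattus norvegicus as the target, read by paw edema, with stated times of 60 min and 2 h, at a dose of 100 mg/kg by the oral route (on this read-out lower numbers stand for less inhibition and higher numbers for more inhibition at the one dose given (going by the name of the read-out)), compound 1 gives 34%. Compound 2 `CCCCCCNC(=O)CC1CCc2cc(OC)c(OC)cc21` carries one more methyl on its chain, and in this assay compound 2 gives 41.5%. The only measured step is a number 7.5 percentage points higher from compound 1 to compound 2 (within the scatter), so compound 2 sits at the upper end of the two numbers shown, yet cannot be set apart from compound 1.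

Compound 3 `COc1cc2c(cc1OC)C(CC(=O)N1CCNCC1)CC2` differs from compound 2 by piperazin-1-yl in place of hexylamino on a carbonyl carbon. Among the measured compounds shown here, no measured step touches the group on the carbonyl carbon; the one step known concerns the chain alone and lies within the scatter. There is thus no basis for expecting a shift in either direction in this assay, only a value near compound 2 with wide uncertainty. Compound 3 is therefore estimated at 38%, in the range 15% to 60%, which means an expected step of a number 3.5 percentage points lower from compound 2 to compound 3 (within the scatter).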

Compound 3, a percentage reported as inhibition, in the whole organism at one dose (the size of the read-out at that dose, not a potency): 44%
Estimate against measurement, compound 3: 6 percentage points below; measured number inside the range.
By their numbers in this assay, from the lowest: compounds 1, 2 and 3 (each within the scatter of the next).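

In this assay the group on a carbonyl carbon can change from an open chain to a ring with the number staying within the scatter: piperazin-1-yl in place of hexylamino gives a number 2.5 percentage points higher from compound 2 to compound 3 (within the scatter), and piperazin-1-yl in place of pentylamino gives a number 10 percentage points higher from compound 1 to compound 3 (within the scatter). The earlier step touched only the chain length, whereas this one replaces the whole amine part of the amide, so this position accepts a much larger structural change without a readable shift at this one dose. Nothing available explains why the numbers stay so close.

Still open, from the compounds shown here alone, is whether the ring or its second nitrogen matters, which piperidin-1-yl or morpholin-4-yl on the same carbonyl carbon would help to separate. Also open, going by these compounds, is whether any group here moves the number beyond the scatter, which 4-methylpiperazin-1-yl or a carboxylic acid could test.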